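The source may report more compounds than this note shows. Statements on the series, on what has been measured and on what is new or still open speak of the compounds shown alone.

Measured so far:
compound 1 `CC/C=C\C/C=C\C/C=C\C/C=C\C/C=C\C/C=C\CCC(=O)OC[C@H]1O[C@H](C2CCCC=C2C)C=CC1=O` gives 20 nM
compound 2 `CC/C=C\C/C=C\C/C=C\C/C=C\C/C=C\C/C=C\CCC(=O)OC[C@@H]1C=CC(=O)[C@@H](C2CCCC=C2C)O1` gives 65000 nM
compound 3 `CC/C=C\C/C=C\C/C=C\C/C=C\C/C=C\C/C=C\CCC(=O)OC[C@@H]1C=CC(=O)[C@@H](CC2=CCCCC2)O1` gives 30000 nM

All three values come from a functional assay on LFCl2A cells (Rattus norvegicus) for cytotoxicity; a lower number here means a stronger inhibitor, a higher number a weaker inhibitor. Compound 1 gives the lowest number; compound 3 and compound 2 stand far higher, and the difference between the core of compound 1 and the core of compound 2 is not broken down here. On the core of compound 2 the change (cyclohex-1-en-1-yl)methyl in place of 2-methylcyclohex-2-en-1-yl on a saturated ring carbon made a step of a 2.2-fold lower number from compound 2 to compound 3 (0.34 log units; beyond the scatter). The same change, at the same place, on the core of compound 1 gives compound 4 `CC/C=C\C/C=C\C/C=C\C/C=C\C/C=C\C/C=C\CCC(=O)OC[C@H]1O[C@H](CC2=CCCCC2)C=CC1=O`, not yet measured in this assay: (cyclohex-1-en-1-yl)methyl in place of 2-methylcyclohex-2-en-1-yl on a saturated ring carbon. The step from compound 1 to compound 4 is expected to be small, a 1.3-fold lower number from compound 1 to compound 4 (0.12 log units; within the scatter), which rests on the earlier step of a 2.2-fold lower number from compound 2 to compound 3 (0.34 log units; beyond the scatter), carried over from a much weaker core. Compound 4 is estimated at 15 nM, expected between 4 nM and 60 nM.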

Compound 4, half-maximal inhibitory concentration: 50 nM
Beside the measured number, compound 4's estimate is 3.3-fold (0.52 log units) below it, within the range that was stated.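

In this assay, replacing 2-methylcyclohex-2-en-1-yl with (cyclohex-1-en-1-yl)methyl on the core of compound 1 gave a 2.5-fold higher number from compound 1 to compound 4 (0.40 log units; beyond the scatter). The step does not carry over between the two cores in direction or in size: the same change on two cores in this assay, a 2.2-fold lower number (0.34 log units; beyond the scatter) from compound 2 to compound 3 and a 2.5-fold higher number (0.40 log units; beyond the scatter) from compound 1 to compound 4, 5.4-fold (0.73 log units) apart, beyond the scatter of two such steps. This shows that a step read on the core of compound 2 is a poor guide to the same change on the core of compound 1, but with one pair per core it does not show why the steps differ or whether other changes behave likewise.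

Still open, from the compounds shown here alone, is how an amine or a carboxylic acid at the same place would read on the core of compound 1. Also open, going by these compounds, is what a shorter chain would do in place of the long ester chain.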